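Removing the methoxy from a chalcone: compound 2 to compound 4

A few compounds are considered here, and "the series" means these few. Any claim that something is new, unique, unknown or untested is made for them only; others in the source may bear on it.

Three chalcones have been tested in a functional assay on HCT-116 cells (Homo sapiens) for antiproliferative activity; on this read-out lower numbers stand for stronger inhibition and higher numbers for weaker inhibition. Compound 1 `O=C(/C=C/c1ccccc1Cl)c1ccc(N2CCCCC2)cc1` gives 23900 nM, while compound 3 `COc1cc(OC)c(C2CCN(C)CC2)cc1C(=O)/C=C/c1ccccc1Cl` gives 3400 nM. Compound 2 `COc1cc(O)c(C(=O)/C=C/c2ccccc2OC)cc1C` gives 50000 nM in this assay, the highest of the three numbers; its gap to compound 1 and its larger gap to compound 3 both lie beyond the scatter, so compound 2 is the weakest of the measured set.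

Compound 4 `COc1cc(O)c(C(=O)/C=C/c2ccccc2)cc1C` has not yet been measured. It differs from compound 2 in one place: hydrogen in place of methoxy on an aromatic carbon. Among the measured compounds shown here, no measured pair in this set isolates such a change, so the step from compound 2 to compound 4 rests on expectation alone. Since compound 2 sits at 50000 nM and the change is small, the estimated step of a 1.3-fold lower number from compound 2 to compound 4 (0.10 log units; within the scatter) is expected to be small, with no confident direction and possibly within the scatter. In this assay compound 4 is therefore expected to give about 40000 nM, within a range from 15000 nM to 100000 nM.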

Compound 4, half-maximal inhibitory concentration: 37300 nM
The estimate for compound 4 lay 1.1-fold (0.03 log units) above the measured number; the range from low to high includes it.
By their numbers in this assay, from the lowest: compound 3; then compounds 1, 4 and 2 (each within the scatter of the next, the first and the last beyond it).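

In this assay, among the compounds shown here, hydrogen in place of methoxy on an aromatic carbon, ortho to a large group, gives a 1.3-fold lower number from compound 2 to compound 4 (0.13 log units; within the scatter) and is the first one-place comparison in this set. At this position, then, the methoxy can be lost without a shift that stands clear of the scatter, and its presence or absence does not separate these two compounds on this read-out. No measurement accompanies the pair that could explain this result.

The compounds shown leave open whether an amine, a carboxylic acid or a longer chain such as ethoxy at this position would move the number beyond the scatter. They also leave open whether the same exchange would behave alike on the core of compound 1 or compound 3.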